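This account rests on a few compounds, and the source may have more. Where it says the series, first, only, none or still open, it means among the compounds named here.

Measured compounds in a physicochemical assay for permeability, using PAMPA, at pH 7.4; a lower number here means that the compound crosses the layer more slowly, a higher number that the compound crosses the layer faster:
- compound 1, `O=C(NS(=O)(=O)c1ccc(F)cc1)c1ccc(Nc2nc(NC3(c4ccc(Cl)cc4)CC3)nc(OCC(F)(F)F)n2)cc1`: 193 nm/s
- compound 2, `O=C(NS(=O)(=O)c1ccccc1)c1ccc(Nc2nc(NC3(c4ccc(Cl)cc4)CC3)nc(OCC(F)(F)F)n2)cc1`: 182 nm/s

Compound 2 stands lowest of the two numbers in this assay; its nearest neighbour is compound 1, and the step of a 1.1-fold lower number from compound 1 to compound 2 (0.03 log units; within the scatter) lies within the scatter, so the two are not separable. For the measured compounds named here, the only measured step, hydrogen in place of fluoro on an aromatic carbon, gave no change beyond the scatter.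

Compound 3, `Cc1ccccc1S(=O)(=O)NC(=O)c1ccc(Nc2nc(NC3(c4ccc(Cl)cc4)CC3)nc(OCC(F)(F)F)n2)cc1`, remains to be measured in this assay. It differs from compound 2 by methyl in place of hydrogen on an aromatic carbon, placed ortho to a large group. Going by the values given here, no measured step covers methyl in place of hydrogen on an aromatic carbon; the one step available, a 1.1-fold lower number from compound 1 to compound 2 (0.03 log units; within the scatter), was within the scatter and concerned a different substituent. The expected step of a 1.0-fold higher number from compound 2 to compound 3 (0.02 log units; within the scatter) is therefore no change beyond the scatter. For compound 3 the estimate in this assay is 190 nm/s, in the range 110 nm/s to 330 nm/s.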

Compound 3, apparent permeability: 265 nm/s
For compound 3 the middle estimate is 1.4-fold (0.14 log units) below the measured one; measured number inside the range.
By their numbers in this assay, from the lowest: compounds 2, 1 and 3 (each within the scatter of the next).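

In this assay, methyl in place of hydrogen on this aromatic carbon, ortho to a large group, gives a 1.5-fold higher number from compound 2 to compound 3 (0.16 log units; within the scatter) and cannot be told apart from no change. The wider replacement of 4-fluorophenyl by 2-methylphenyl on the sulfonyl sulfur gives a 1.4-fold higher number from compound 1 to compound 3 (0.14 log units; within the scatter) and is likewise not separable. Across 4-fluorophenyl, phenyl and 2-methylphenyl, every step in this assay stays within the scatter, so this position now has two different substituents that leave the number unresolved from that of the unsubstituted phenyl.

Nothing shown accounts for how close these numbers lie. As far as these compounds go, whether an amine or a carboxylic acid on this ring, or a longer chain in place of methyl, would give a step beyond the scatter remains open.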